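Shortening the ring-nitrogen substituent: from compound 2 to compound 3

This account rests on a few compounds, and the source may have more. Where it says the series, first, only, none or still open, it means among the compounds named here.

Measured so far:
- compound 1, `CC(C)n1nc(-c2ccnc3[nH]c(C4CCN(CC(=O)N(C)C)CC4)cc23)ccc1=O`: 3.1 uL/min
- compound 2, `CN(C)C(=O)CN1CCC(c2cc3c(-c4ccc(=O)n(CC5CCOCC5)c4)ccnc3[nH]2)CC1`: 1.8 uL/min

Both compounds were run in an ADME assay on cells (Hepatocyte, Rattus norvegicus) for metabolic stability; on this read-out lower numbers stand for slow clearance and higher numbers for fast clearance. Of the two numbers, compound 2 carries the lower one, but its gap to compound 1 is within the scatter, so the two stand as alike for practical purposes.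

Compound 3, `CN(C)C(=O)CN1CCC(c2cc3c(-c4ccc(=O)n(C)c4)ccnc3[nH]2)CC1`, has not yet been measured. It differs from compound 2 in one place: hydrogen in place of oxan-4-yl on a saturated chain carbon bound to an aromatic nitrogen. Put otherwise, a (oxan-4-yl)methyl group becomes a methyl group on the same nitrogen.

Within the data shown here, with only two measured compounds, and those two indistinguishable, there is no measured step to lean on. The expectation is therefore a step of a 1.1-fold higher number from compound 2 to compound 3 (0.05 log units; within the scatter), that is, no change beyond the scatter. Compound 3 is expected to give about 2 uL/min in this assay, with a plausible range from 0.8 uL/min to 4.5 uL/min.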

Compound 3, intrinsic clearance in a liver preparation (reported as CLH), per the amount of preparation that the assay uses in the Hepatocyte assay: < 1 uL/min
Compound 3 was reported as a limit; the forecaster's own chance of this, stated with the estimate: 10%; middle value at least 2.0-fold (0.30 log units) from the limit.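

In the Hepatocyte assay, the reading for compound 3 is a limit and not a number: the limit of < 1 uL/min in the Hepatocyte assay, at which 1 of the 3 values shown sits. Read with that limit, the Hepatocyte assay shows an at least 3.1-fold lower number from compound 1 to compound 3 (0.49 log units; beyond the scatter), a clear separation, while it shows an at least 1.8-fold lower number from compound 2 to compound 3 (0.25 log units; that floor lies within the scatter), so swapping (oxan-4-yl)methyl for methyl may or may not have moved clearance beyond the scatter. In a physicochemical assay for lipophilicity, using the shake flask method, measured as octanol-water partition, at pH 7.4 (on this read-out higher numbers stand for higher lipophilicity and lower numbers for lower lipophilicity), compound 2 gives 1.4 and compound 3 gives 1.1, two values within the scatter of each other, so the oxan-4-yl ring can go without a distinct difference on this read-out.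

On these data alone, the true clearance of compound 3 remains unknown, and so does the full size of both steps. Also open, as far as these compounds go, is whether an ethyl group, a longer chain or a chain ending in an amine, in place of the methyl, would keep clearance this slow.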